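Inverting both ring centres of the phenylpropyl analogue

A few compounds are considered here, and "the series" means these few. Any claim that something is new, unique, unknown or untested is made for them only; others in the source may bear on it.

Compound 2 `O=C(NO)c1cccc(-c2cn([C@H]3C[C@H](CO)N(CCCc4ccccc4)C3)nn2)c1` stands at the floor of an assay on Sf9 cells for inhibition of histone deacetylase 11 (Homo sapiens), read by fluorescence, tested at 0.5 uM (on this read-out lower numbers stand for less inhibition and higher numbers for more inhibition at the one concentration tested (going by the name of the read-out)), rather than at a number. In this assay compound 2 gives < 10%, which is a limit of the assay and not a measured value. Compound 1 `O=C(NO)c1cccc(-c2cn([C@@H]3C[C@@H](CO)N(Cc4ccccc4)C3)nn2)c1` sits at that same floor: in this assay compound 1 gives < 10%, again a limit. Going by the values given here, compound 3 `O=C(NO)c1ccc(-c2cn([C@H]3C[C@H](CO)N(CCCc4ccccc4)C3)nn2)cc1`, with 4-(hydroxycarbamoyl)phenyl in place of 3-(hydroxycarbamoyl)phenyl on an aromatic carbon, is the only member with a number: in this assay compound 3 gives 18%. Among the compounds with values here, the single step between measured compounds, a number at least 8 percentage points higher from compound 2 to compound 3 (that floor lies within the scatter), concerns that phenyl substitution and not the saturated ring, so it does not bear on the change considered here.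

Compound 4 `O=C(NO)c1cccc(-c2cn([C@@H]3C[C@@H](CO)N(CCCc4ccccc4)C3)nn2)c1` is the mirror image of compound 2: the two compounds have the same atoms and bonds and differ only in configuration as drawn: 2 of 2 stereo elements differ (all stereocentres are inverted: mirror images); a stereocentre at a saturated ring carbon is drawn S in compound 2 and R in compound 4; a stereocentre at a saturated ring carbon is drawn R in compound 2 and S in compound 4. Within the data shown here, no measured pair isolates such an inversion of both centres, so there is no step to lean on; what is known is the limit of < 10% in this assay, at which 2 of the 3 values shown sit. With two of three values already at the floor and no evidence that the configuration moves the read-out, the expected step that the limit leaves unreadable from compound 2 to compound 4 is none beyond the scatter, and compound 4 will most probably be reported at the limit too. Compound 4 is estimated at 7% in this assay, with a range from 0% to 18%.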

Compound 4, a percentage reported as inhibition, at one concentration (the size of the read-out at that concentration, not a potency): < 10%
Compound 4: only a limit was reported (the forecaster's own chance of this, stated with the estimate: 70%); the middle value is on the limit's open side.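

In this assay compound 4 gives < 10%, which is a limit and not a number. Compounds 1 and 2 also stand at limits, so the steps to compound 4 from compound 1 and from compound 2 cannot be read. On these data alone, whether inverting both ring centres changes inhibition at all stays open, as the mirror-image pair of compound 2 and compound 4 offers no number on either side.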